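The source may report more compounds than this note shows. Statements on the series, on what has been measured and on what is new or still open speak of the compounds shown alone.

Measured in an ADME assay on TZM cells (Homo sapiens) for cytotoxicity, read by MTT assay, with a stated time of 5 days; a higher number here means that more compound is tolerated, a lower number that less compound is tolerated:
- compound 1 `Cc1cn([C@H]2C[C@H](N=[N+]=[N-])[C@@H](COC(=O)CCC(=O)OCSc3ccccc3CNCCC(N)=O)O2)c(=O)[nH]c1=O`: > 1650 nM
- compound 2 `Cc1cn([C@H]2C[C@H](N=[N+]=[N-])[C@@H](COC(=O)CCCC(=O)OCSc3ccccc3CNCCC(N)=O)O2)c(=O)[nH]c1=O`: > 1610 nM
- compound 3 `Cc1cn([C@H]2C[C@H](N=[N+]=[N-])[C@@H](COC(=O)CC(C)CC(=O)OCSc3ccccc3CNCCC(N)=O)O2)c(=O)[nH]c1=O`: > 1580 nM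

All three results are limits and not numbers. Compound 3 therefore stands at a limit, > 1580 nM. Compound 4 `Cc1cn([C@H]2C[C@H](N=[N+]=[N-])[C@@H](COC(=O)CC(C)(C)CC(=O)OCSc3ccccc3CNCCC(N)=O)O2)c(=O)[nH]c1=O` carries one change: methyl in place of hydrogen on a saturated chain carbon bound to three saturated chain carbons, which is methyl in place of hydrogen on a saturated chain carbon bound to three saturated chain carbons. Among the compounds with values here, the one measured step that bears on this is a step that the two limits leave unreadable from compound 2 to compound 3, and there methyl replaced hydrogen on a saturated chain carbon bound to two saturated chain carbons. That step gives no readable size, so it offers no sign of a change. Expected, then, is an at least 1.0-fold lower number from compound 3 to compound 4 (0.00 log units; that floor lies within the scatter), nothing beyond the usual scatter. For compound 4 the estimate is 1550 nM, with an expected range of 1200 nM to 2500 nM, most likely reported as a limit again.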

Compound 4, half-maximal cytotoxic concentration: > 1540 nM
Compound 4 ended at the assay's limit; the forecaster's own chance of this, stated with the estimate: 90%; the middle value lies beyond the limit too.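

Compound 4 gives > 1540 nM, a limit and not a number. Within the data shown here, compound 3 also stands at a limit, so no step between compound 3 and compound 4 can be read. The compounds shown leave open where the half-maximal cytotoxic concentration of each actually lies.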